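The source may hold more compounds than are shown below. What is called first, only, known or untested is meant among the compounds shown, and "the series" means these compounds.

Measured so far:
compound 1 `Fc1ccccc1CSc1nnc(-c2ccncc2)n1-c1ccccc1` — in a functional assay on MCF7 cells (Homo sapiens) for inhibition, read by MTT assay, with a stated time of 48 h (a higher number here means a weaker inhibitor, a lower number a stronger inhibitor), compound 1 gives only a limit, > 50000 nM.
compound 2 `O=[N+]([O-])c1ccc(CSc2nnc(-c3ccncc3)n2-c2ccccc2)cc1` — compound 2 gives 22800 nM.
compound 3 `O=C(CSc1nnc(-c2ccncc2)n1-c1ccccc1)N/N=C/c1ccc([N+](=O)[O-])cc1` — compound 3 gives 15300 nM.

Compound 3 and compound 2 lie within the scatter of each other, while compound 1 sits at the limit (the limit of > 50000 nM in this assay, at which 1 of the 3 values shown sits). Compound 4 `O=C(CSc1nnc(-c2ccncc2)n1-c1ccccc1)N/N=C/c1ccccc1O` differs from compound 3 by 2-hydroxyphenyl in place of 4-nitrophenyl on a carbon with a double bond to nitrogen. Among the measured compounds shown here, only one measured step involves an aryl swap, an at least 2.1-fold lower number from compound 1 to compound 2 (0.34 log units; beyond the scatter), and it sits on the saturated chain carbon bound to sulfur, not on the carbon double-bonded to nitrogen; it does show that exchanging the 4-nitrophenyl can move the number. The step from compound 3 to compound 4 is therefore expected to be modest, a 1.6-fold higher number from compound 3 to compound 4 (0.21 log units; within the scatter). Compound 4 is expected to give 25000 nM, probably between 10000 nM and 60000 nM.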

Compound 4, half-maximal inhibitory concentration: 10000 nM
Compound 4: the middle estimate sits 2.5-fold (0.40 log units) above what was measured; measured number inside the range.
By their numbers in this assay, from the lowest: compounds 4, 3 and 2 (each within the scatter of the next, the first and the last beyond it). At a limit, above all of these: compound 1.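

Among the compounds shown here, on the carbon with a double bond to nitrogen, the earlier compounds carried only 4-nitrophenyl. Putting 2-hydroxyphenyl there gives a 1.5-fold lower number from compound 3 to compound 4 (0.18 log units; within the scatter) in this assay, so two differently substituted phenyl groups are tolerated at this position without a step beyond the scatter. Nothing measured here bears on why the two values lie so close.

As far as these compounds go, it remains open whether a phenyl carrying an amine or a carboxylic acid on this carbon would stay within that scatter, and whether 2-hydroxyphenyl would behave alike on the saturated chain carbon bound to a sulfur.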